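A Fluorine Added to the Phenoxy Compound

The compounds below may be only part of what the source reports. "The series", "measured", "known", "first", "only" and "open" are said of these compounds alone.

Compound 1 `O=C1NC(=O)C(Cc2ccc(Cc3ccccc3)cc2)S1` gives 9280 nM in a functional assay for agonist activity at Free fatty acid receptor 1 (Homo sapiens), read by FLIPR, in the presence of a further agent that is not named here; on this read-out higher numbers stand for an effect only at larger amounts of compound and lower numbers for an effect already at smaller amounts. Compound 2 `O=C1NC(=O)C(Cc2ccc(Oc3ccccc3)cc2)S1` gives 307 nM. Compound 3 `O=C1NC(=O)C(Cc2ccc(-c3ccccc3)cc2)S1` gives 2220 nM.

Among these three, compound 2 gives the lowest number, with compound 3 nearest and compound 1 furthest. Both steps toward it are beyond the scatter: a 30-fold lower number from compound 1 to compound 2 (1.48 log units; beyond the scatter), and a 7.2-fold higher number from compound 2 to compound 3 (0.86 log units; beyond the scatter); the remaining step of a 4.2-fold lower number from compound 1 to compound 3 (0.62 log units; beyond the scatter) is also beyond the scatter.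

Compound 4 `O=C1NC(=O)C(Cc2ccc(Oc3ccc(F)cc3)cc2)S1` differs from compound 2 by a single change: fluoro in place of hydrogen on an aromatic carbon.

Within the data shown here, none of the measured steps bears directly on this change. The three steps all concern the group joining the two rings, not a substituent on the outer ring, so they offer no guidance on direction. Compound 2 therefore stands as the plain point of departure, and the step of a 1.2-fold lower number from compound 2 to compound 4 (0.09 log units; within the scatter) is expected to stay within the scatter. Compound 4 is estimated at 250 nM, with a range from 80 nM to 800 nM.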

Compound 4, half-maximal effective concentration: 480 nM
Beside the measured number, compound 4's estimate is 1.9-fold (0.28 log units) below it, and the stated range covers the measured number.
By their numbers in this assay, from the lowest: compounds 2 and 4 (each within the scatter of the next); then compound 3; then compound 1.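

Replacing phenyl with 4-fluorophenyl in this assay gives a 1.6-fold higher number from compound 2 to compound 4 (0.19 log units; within the scatter) and so leaves compound 2 and compound 4 within the scatter of each other. This is the first change shown on the outer ring, and fluoro in place of hydrogen, on an aromatic carbon para to a large group, does not separate the two compounds on this read-out. Each earlier step changed the group joining the two rings and lay beyond the scatter, while this step does not. No measurement offered here accounts for this result.

What the compounds shown leave open is whether a methoxy, a trifluoromethyl or a carboxylic acid in this same place would also stay within the scatter of compound 2. They also leave open whether fluoro on the outer ring of compound 3 would give a step of similar size.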